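A few compounds are considered here, and "the series" means these few. Any claim that something is new, unique, unknown or untested is made for them only; others in the source may bear on it.

Measured so far in an ADME assay on a cell-free system (plasma, Homo sapiens) for metabolic stability, with Plasma (Rattus norvegicus) as the target, read by HPLC, at pH 7.4; a lower number here means that the compound disappears faster, a higher number that the compound lasts longer:
Compound 1 `CCCCC(=O)O[C@@H]1CO[C@H]2[C@@H]1OC[C@@H]2OC(=O)c1ccccc1OC(C)=O`: compound 1 gives 0.0117 h.
Compound 2 `CC(=O)Oc1ccccc1C(=O)O[C@H]1CO[C@H]2[C@@H]1OC[C@H]2OC(=O)C1CC1`: compound 2 gives 0.015 h.
Compound 3 `CC(=O)Oc1ccccc1C(=O)O[C@H]1CO[C@H]2[C@@H]1OC[C@H]2OC(=O)c1ccc(C#N)cc1`: compound 3 gives 0.068 h.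

Compound 3 holds the highest number of the three: the nearest is compound 2, a 4.5-fold higher number from compound 2 to compound 3 (0.66 log units; beyond the scatter), and the furthest is compound 1, a 5.8-fold higher number from compound 1 to compound 3 (0.76 log units; beyond the scatter). Compound 4 `CC(=O)Oc1ccccc1C(=O)O[C@H]1CO[C@H]2[C@@H]1OC[C@H]2OC(=O)CCO[N+](=O)[O-]` differs from compound 3 in one place: 2-(nitrooxy)ethyl in place of 4-cyanophenyl on a carbonyl carbon. Both steps into compound 3 replaced a chain or small ring on that carbonyl carbon with 4-cyanophenyl and raised the number beyond the scatter; compound 4 returns to a chain on that carbonyl carbon. Compound 4 is therefore expected to fall beyond the scatter, a 4.5-fold lower number from compound 3 to compound 4 (0.66 log units; beyond the scatter). The estimate for compound 4 in this assay is 0.015 h, with a range from 0.007 h to 0.04 h.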

Compound 4, half-life: 0.0217 h
Compound 4: middle estimate off by 1.4-fold (0.16 log units), on the low side; the range from low to high includes it.
By their numbers in this assay, from the lowest: compounds 1, 2 and 4 (each within the scatter of the next); then compound 3.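

In this assay, the 2-(nitrooxy)ethyl chain on the carbonyl carbon does not keep what 4-cyanophenyl gained (a 3.1-fold lower number from compound 3 to compound 4 (0.50 log units; beyond the scatter)). It stands level with the two other groups without an aromatic ring (a 1.4-fold higher number from compound 2 to compound 4 (0.16 log units; within the scatter); a 1.9-fold higher number from compound 1 to compound 4 (0.27 log units; within the scatter)), so among these four compounds only 4-cyanophenyl stands apart at this position. Nothing available explains why.

Going by these compounds, it remains open whether plain phenyl, without the nitrile, would stand with 4-cyanophenyl. Also open, on these data alone, is whether a longer chain carrying nitrooxy, or a chain ending in an amine, would stay level with the other chains.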